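Dimethylphenyl in Place of Trifluoromethylphenyl on the Ring Nitrogen

The source may hold more compounds than are shown below. What is called first, only, known or untested is meant among the compounds shown, and "the series" means these compounds.

Compound 1, `CCCc1nc(-c2ccccc2)c(CNCCCN2CCN(c3cccc(C)c3C)CC2)o1`, gives 55.2% in an assay on HEK293 cells for inhibition of Voltage-dependent T-type calcium channel subunit alpha-1G (Homo sapiens), read by fluorescence, tested at 10 uM; a higher number here means more inhibition at the concentration tested (going by the name of the read-out), a lower number less inhibition.
Compound 2, `CCCc1nc(-c2ccccc2)c(CNCCCN2CCN(c3ccc(C(F)(F)F)cc3)CC2)o1`, gives 51.6%.
Compound 3, `CCCc1nc(-c2ccccc2)c(CNCCCN2CCN(c3cccc(C(F)(F)F)c3)CC2)o1`, gives 51.6%.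

Compound 3 sits level with compound 2, the two together giving the lowest numbers of the three; the step of no change at the digits printed from compound 2 to compound 3 (within the scatter) and the step of a number 3.6 percentage points lower from compound 1 to compound 3 (within the scatter) both fall inside the usual scatter, so the three compounds are not told apart by these measurements.

Compound 4, `CCCc1nc(-c2ccccc2)c(CNCCCN2CCN(c3ccc(C)c(C)c3)CC2)o1`, has not been measured. It differs from compound 3 as follows: 3,4-dimethylphenyl in place of 3-(trifluoromethyl)phenyl on an amine nitrogen in a ring.

Going by the values given here, two measured steps bear on this change. The step of a number 3.6 percentage points lower from compound 1 to compound 2 (within the scatter) and the step of a number 3.6 percentage points lower from compound 1 to compound 3 (within the scatter) each replaced a dimethylphenyl with a trifluoromethylphenyl on the ring nitrogen, and neither moved the read-out beyond the scatter. Compound 4 brings a dimethylphenyl back, so the expected step is small: the estimated step is a number 2.4 percentage points higher from compound 3 to compound 4 (within the scatter), not beyond the scatter. Compound 4 is therefore expected to give 54%, with a likely range from 40% to 68%.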

Compound 4, a percentage reported as inhibition, at one concentration (the size of the read-out at that concentration, not a potency): 54.6%
Compound 4: the middle estimate sits 0.6 percentage points below what was measured; measured number inside the range.
By their numbers in this assay, from the lowest: compounds 2, 3, 4 and 1 (each within the scatter of the next).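

In this assay, 3,4-dimethylphenyl in place of 3-(trifluoromethyl)phenyl is a step within the scatter (a step of a number 3 percentage points higher from compound 3 to compound 4 (within the scatter)), and the same holds for the swap from 4-(trifluoromethyl)phenyl (a step of a number 3 percentage points higher from compound 2 to compound 4 (within the scatter)). New here is a pair with the same two substituents arranged differently on the phenyl: 3,4-dimethylphenyl in place of 2,3-dimethylphenyl is also within the scatter (a step of a number 0.6 percentage points lower from compound 1 to compound 4 (within the scatter)), so this assay tells neither the methyl arrangement nor methyl from trifluoromethyl apart at this position. Nothing available here offers an explanation for these results.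

The compounds shown leave open whether a different substituent on this phenyl, such as a methoxy group or an amine, would move the read-out beyond the scatter. They also leave open what a change elsewhere, such as a longer chain on the shared core, would do.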